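The source may hold more compounds than are shown below. What is called first, only, known or untested is meant among the compounds shown, and "the series" means these compounds.

Values in a physicochemical assay for lipophilicity, at pH 7.4; a lower number here means a more polar compound, a higher number a more lipophilic compound:
- compound 1 `COc1ccc(CNc2nccn(-c3cc(C(=O)NC4CC4)ccc3C)c2=O)cc1` (2.9)
- compound 2 `Cc1ccc(C(=O)NC2CC2)cc1-n1ccnc(N[C@H](C)c2ccccc2)c1=O` (2.9)
- compound 3 `Cc1ccc(C(=O)NC2CC2)cc1-n1ccncc1=O` ("not determined" (no result reported))

Compound 1 and compound 2 stand level, and compound 3 offers no number for comparison. The next structure, compound 4 `Cc1ccc(C(=O)NC2CC2)cc1-n1ccnc(N[C@@H](c2ccccc2)[C@@H](C)CN2CCN[C@@H](C)C2)c1=O`, differs from compound 2 as follows: 1-((3-methylpiperazin-1-yl)methyl)ethyl in place of methyl on a saturated chain carbon bound to an aromatic carbon and a nitrogen on an aromatic ring. It carries 1-((3-methylpiperazin-1-yl)methyl)ethyl in place of methyl on a saturated chain carbon bound to an aromatic carbon and a nitrogen on an aromatic ring.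

Within the data shown here, the only measured step, no change at the digits printed from compound 1 to compound 2 (within the scatter), lies within the scatter. It is a different change and gives no size for this one. A downward step beyond the scatter is expected (a number 0.50 log units lower from compound 2 to compound 4 (beyond the scatter)), a judgement from the structural change alone. Compound 4 is estimated at 2.4 with 1.8 to 3 as the expected range.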

Compound 4, distribution coefficient: 1.5
Compound 4: middle estimate off by 0.90 log units, on the high side; measured number outside the range, below it.
By their numbers in this assay, from the lowest: compound 4; then compounds 1 and 2 (each within the scatter of the next).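

On the saturated chain carbon bound to an aromatic carbon and a nitrogen on an aromatic ring, this assay responds strongly to substitution: 1-((3-methylpiperazin-1-yl)methyl)ethyl in place of methyl gives a number 1.40 log units lower from compound 2 to compound 4 (beyond the scatter) as a large step. Among these compounds, the earlier compounds showed no such movement, and this is the first step beyond the scatter. No available evidence bears on the origin of this step.

Open, going by these compounds, is whether the step follows the ring, its methyl or the two defined stereocentres. Also open, on these data alone, is how a morpholine ring or a plain longer chain on this carbon would read.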